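The compounds below may be only part of what the source reports. "The series", "measured", "known", "first", "only" and "open" are said of these compounds alone.

This study follows a small set of compounds built on one shared core and tested in an ADME assay on MT2 cells (Homo sapiens) for cytotoxicity; on this read-out higher numbers stand for lower toxicity in this test and lower numbers for higher toxicity in this test. Compound 1 `COc1nc(Nc2ccc(Cl)c(OCC=C(C)C)c2)nc(OC)n1` gives 20000 nM in this assay. Compound 2 `COc1ncnc(Nc2ccc(C#N)c(OCC=C(C)C)c2)n1` gives 42000 nM, the highest of the three numbers, with compound 1 somewhat lower and compound 3 much lower. Compound 3 `CC(C)=CCOc1cc(Nc2ncnc(N)n2)ccc1C#N` gives 200 nM. Going by the values given here, the only change recorded as a single step is a 210-fold lower number from compound 2 to compound 3 (2.32 log units; beyond the scatter). Compound 4 `COc1nc(Nc2ccc(C#N)c(OCC=C(C)C)c2)nc(OC)n1` has not yet been measured; it differs from compound 2 in one place: methoxy in place of hydrogen on an aromatic carbon. The recorded step exchanges one group for another and does not add a methoxy group, so it bears only loosely on this change. Compound 1, which also carries two methoxy groups on its core, gives a number close to that of compound 2, though the two differ in more than one place. The expected step is therefore a 1.4-fold lower number from compound 2 to compound 4 (0.15 log units; within the scatter), not clearly beyond the scatter. Compound 4 is estimated at 30000 nM, with a likely range from 10000 nM to 90000 nM.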

Compound 4, half-maximal cytotoxic concentration: > 100000 nM
Compound 4 was reported as a limit (the forecaster's own chance of this, stated with the estimate: 10%); at least 3.3-fold (0.52 log units) between middle value and limit.
By their numbers in this assay, from the lowest: compound 3; then compound 1; then compound 2. At a limit, above all of these: compound 4.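

In this assay compound 4 stands at a limit and not at a number: the limit of > 100000 nM in this assay, at which 1 of the 4 values shown sits.

On the aromatic carbon between two ring nitrogen atoms, methoxy in place of hydrogen gives an at least 2.3-fold higher number from compound 2 to compound 4 (0.37 log units; beyond the scatter), so a change at this position alone moves the number towards lower toxicity in this test. Cyano in place of chloro, with the two methoxy groups on the core unchanged, gives an at least 5.0-fold higher number from compound 1 to compound 4 (0.69 log units; beyond the scatter), which shows that this exchange also counts, something compound 1 and compound 2 could not show as they differ in more than one place.

As far as these compounds go, whether the shift belongs to methoxy in particular stays open, and an amine, an ethoxy group or a chlorine atom on this same carbon would help to settle it. Also open, from the compounds shown here alone, is whether the much lower number of compound 3, 200 nM, would hold with methoxy on this carbon.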